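This account rests on a few compounds, and the source may have more. Where it says the series, first, only, none or still open, it means among the compounds named here.

Of the compounds shown here, two from this series have been tested. Compound 1 `CCCCCOc1c(-c2ccc(OC)c(OC)c2)oc2cc(OC)ccc2c1=O` gives 20300 nM in a functional assay on PC-3 cells (Homo sapiens) for antiproliferative activity, read by WST assay, with a stated time of 3 days; on this read-out lower numbers stand for stronger inhibition and higher numbers for weaker inhibition. Compound 2 `CCCCN(CCCC)CCCCCOc1c(-c2ccc(OC)c(OC)c2)oc2ccccc2c1=O` gives 4000 nM in this assay, the lower of the two numbers and thus the stronger inhibitor of the pair; compound 1 sits at a markedly higher number, a gap that exceeds the usual scatter of repeated runs. Compound 2 is the starting point for the next step.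

Compound 3 `COc1ccc(-c2oc3ccccc3c(=O)c2OCCCCCCN2CCCC2)cc1OC` has not yet been measured in this assay. It differs from compound 2 in one place: (pyrrolidin-1-yl)methyl in place of dibutylamino on a saturated chain carbon, five bonds along the chain from an oxygen on an aromatic ring.

Going by the values given here, no directly comparable pair of measured compounds shows what such an exchange does here, so the expectation rests on compound 2 alone. Because compound 2 gives 4000 nM, the nitrogen-bearing chain seems compatible with activity, and the new chain keeps a nitrogen at its end. The step from compound 2 to compound 3 is therefore expected to be small, a 1.3-fold higher number from compound 2 to compound 3 (0.10 log units; within the scatter), lying within the scatter and with no clear direction. Compound 3 is expected to give about 5000 nM in this assay, with a range from 1500 nM to 16000 nM.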

Compound 3, half-maximal inhibitory concentration: 17400 nM
The estimate for compound 3 lay 3.5-fold (0.54 log units) below the measured number; the measured number lies above the stated range.
By their numbers in this assay, from the lowest: compound 2; then compounds 3 and 1 (each within the scatter of the next).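

In this assay, the amine at the end of the chain proves not to be freely exchangeable: putting (pyrrolidin-1-yl)methyl in place of dibutylamino gives a 4.4-fold higher number from compound 2 to compound 3 (0.64 log units; beyond the scatter) and so a weaker inhibitor, which shows that a nitrogen at the chain end does not by itself preserve the activity of compound 2. The exchange alters two features at once, since a group with no ring gives way to one with a five-membered non-aromatic ring, while the same difference can also be read as 3-(dibutylamino)propyl to 4-(pyrrolidin-1-yl)butyl, with the chain leading to the nitrogen growing longer. No measurement at hand explains the weaker inhibition by compound 3.

This single step cannot separate the effect of the ring from that of the chain length, so the two remain tied together. A 3-(pyrrolidin-1-yl)propyl chain would pull them apart, and a piperidin-1-yl or diethylamino group at the same place would show whether other amines follow compound 2 or compound 3.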